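Swapping a phenoxy for an ethylsulfanyl chain end

The source may hold more compounds than are shown below. What is called first, only, known or untested is meant among the compounds shown, and "the series" means these compounds.

Measured compounds:
compound 1, `CN1CCN(c2nc3ccccc3n2CCOc2ccccc2)CC1`: 6.9 nM
compound 2, `C=CCOCCn1c(N2CCCN(C)CC2)nc2ccccc21`: 10 nM

In a functional assay on ileum for inhibition of histamine H1 receptor (Cavia porcellus) (on this read-out higher numbers stand for weaker inhibition and lower numbers for stronger inhibition), compound 1 gives 6.9 nM, the lowest of the two numbers shown, and compound 2 gives 10 nM, a number that sits within the scatter of compound 1, so neither can be called stronger than the other. Compound 1 and compound 2 differ in more than one place, so their two numbers can only be taken as they stand.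

Compound 3, `CCSCCn1c(N2CCN(C)CC2)nc2ccccc21`, has not yet been measured in this assay. It differs from compound 1 in one place: ethylsulfanyl in place of phenoxy on a saturated chain carbon, two bonds along the chain from an aromatic nitrogen. Among the compounds with values here, no measured pair shows this kind of change, so there is nothing to size the step from. The expectation is a step from compound 1 to compound 3 of a 1.6-fold higher number from compound 1 to compound 3 (0.20 log units; within the scatter), small and within the scatter or a little weaker. Compound 3 is therefore estimated at 11 nM, with a range from 3.5 nM to 35 nM.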

Compound 3, half-maximal inhibitory concentration: 19 nM
Beside the measured number, compound 3's estimate is 1.7-fold (0.24 log units) below it, within the range that was stated.
By their numbers in this assay, from the lowest: compounds 1, 2 and 3 (each within the scatter of the next, the first and the last beyond it).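

Within the data shown here, this is the first step that sizes a change at this chain end: in this assay, ethylsulfanyl in place of phenoxy on a saturated chain carbon, two bonds along the chain from an aromatic nitrogen, gives a 2.8-fold higher number from compound 1 to compound 3 (0.44 log units; beyond the scatter). The step is modest, so what sits at this chain end does move the number, yet compound 3, whose new group has no ring and fewer heavy atoms, still gives 19 nM. Nothing measured here explains the step.

Phenoxy and ethylsulfanyl differ at once in the ring, in the heavy-atom count and in oxygen against sulfur, so the share of each in this step stays open. An ethoxy or a phenylsulfanyl group at the same place would change only some of these at a time.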